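The source may hold more compounds than are shown below. What is called first, only, known or untested is meant among the compounds shown, and "the series" means these compounds.

Measured compounds:
Compound 1 `CCCCCc1cn(Cc2ccccc2O)nn1`: > 20000 nM
Compound 2 `CCCCCc1c(CO)nnn1Cc1ccc2ccccc2c1`: > 20000 nM

In an ADME assay on Vero cells (Chlorocebus sabaeus) for cytotoxicity, read by neutral red uptake, with a stated time of 48 h (on this read-out lower numbers stand for stronger inhibition and higher numbers for weaker inhibition), compound 1 gives > 20000 nM, a limit of the assay rather than a number. Compound 2 likewise reaches only > 20000 nM, again a limit. Going by the values given here, both values therefore sit at the limit of > 20000 nM in this assay, at which 2 of the 2 values shown sit, so compound 1 cannot be placed relative to compound 2, and no measured step between two numbered values exists here.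

Compound 3 `CCCc1cn(Cc2ccccc2O)nn1` is yet to be measured in this assay. It differs from compound 1 by hydrogen in place of ethyl on a saturated chain carbon, three bonds along the chain from an aromatic carbon. Since compound 1 already shows only a limit in this assay, the step from compound 1 to compound 3 is expected to be a step that the limit leaves unreadable from compound 1 to compound 3, that is, nothing beyond the usual scatter. For compound 3 in this assay the estimate is 30000 nM, within a range from 10000 nM to 100000 nM, most likely reported once more as a limit.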

Compound 3, half-maximal inhibitory concentration: > 20000 nM
Compound 3: only a limit was reported; the forecaster's own chance of this, stated with the estimate: 80%; the middle value does not contradict the limit.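

No step from compound 1 to compound 3 can be read, for compound 3 too gives only a limit, > 20000 nM, and not a number: the limit of > 20000 nM in this assay, at which 3 of the 3 values shown sit.

The compounds shown leave open whether pentyl or propyl makes any difference in this assay, and how far any compound lies from that limit.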